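The compounds below may be only part of what the source reports. "The series", "measured", "known", "first", "only" and "open" are said of these compounds alone.

Compound 1 `COc1ccc(C2=C(c3ccc(SC)cc3)CC3CCCN3C2=O)cc1Br`: 800 nM
Compound 2 `COc1ccc(C2=C(c3ccc(SC)cc3)CC3CCCN3C2=O)cc1`: 2000 nM

For the measured compounds named here, in a functional assay on U-251 cells (Homo sapiens) for cytotoxicity (on this read-out higher numbers stand for weaker inhibition of growth and lower numbers for stronger inhibition of growth), compound 2 gives 2000 nM, the higher of the two numbers so far. Compound 3 `CSc1ccc(C2=C(c3ccc(OCC4CO4)cc3)C(=O)N3CCCC3C2)cc1` keeps the shared core of compound 2 but turns its methoxy into (oxiran-2-yl)methoxy, with oxiran-2-yl in place of hydrogen on a saturated chain carbon bound to an oxygen on an aromatic ring. Going by the values given here, only one measured step is available, a 2.5-fold higher number from compound 1 to compound 2 (0.40 log units; beyond the scatter), and it is a modest one. It concerns hydrogen in place of bromo on an aromatic carbon, a different change, so it bears on this one only loosely and gives no direction. The size of that step suggests a modest effect at most, and no step beyond the scatter is expected in this assay. The expected change is a 1.3-fold lower number from compound 2 to compound 3 (0.12 log units; within the scatter). For compound 3 the estimated value is 1500 nM, with an expected range from 400 nM to 6000 nM.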

Compound 3, concentration for 50% growth inhibition: 80 nM
The estimate for compound 3 lay 19-fold (1.27 log units) above the measured number, and the stated range ends above it.
By their numbers in this assay, from the lowest: compound 3; then compound 1; then compound 2.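

In this assay, the methoxy group of compound 2 proves to be a place where a change counts: with (oxiran-2-yl)methoxy in its stead there is a 25-fold lower number from compound 2 to compound 3 (1.40 log units; beyond the scatter), a large step. For the compounds shown here, the only earlier step, a 2.5-fold higher number from compound 1 to compound 2 (0.40 log units; beyond the scatter), is a modest one and concerns bromo and hydrogen on an aromatic carbon, so it gave no sign that a step of this size could occur with the shared core. Here the added oxiran-2-yl on the saturated chain carbon bound to an oxygen on an aromatic ring accounts for a far larger shift in number.

The compounds shown leave open whether the three-membered ring itself matters, or whether a plain propyl chain or a 2,3-dihydroxypropyl group on that oxygen would give a similar number. Nothing available offers a measured explanation for the step.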